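A Methylsulfonyl Group on the Shared Core

A few compounds are considered here, and "the series" means these few. Any claim that something is new, unique, unknown or untested is made for them only; others in the source may bear on it.

Of the compounds shown here, three built on a shared core have been tested in a functional assay on the whole organism for antagonist activity, with Mus musculus as the target (on this read-out higher numbers stand for an effect only at larger amounts of compound and lower numbers for an effect already at smaller amounts), and none of them has yet given a number. Compound 1 `CSc1nc(-c2ccc(Cl)cc2)nn1C` gives > 200 mg/kg, which is a limit. Compound 2 `CSc1nc(-c2ccccc2)n(C)n1` gives > 100 mg/kg, which is also a limit. Compound 3 `Cn1nc([S+](C)[O-])nc1-c1ccccc1` gives > 200 mg/kg, again a limit. Compound 3 thus stands at the limit of > 200 mg/kg in this assay, at which 2 of the 3 values shown sit. Compound 2 stands at the limit of > 100 mg/kg in this assay, at which 1 of the 3 values shown sits.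

The next compound, compound 4 `Cn1nc(S(C)(=O)=O)nc1-c1ccccc1`, differs from compound 3 by a group of 4 heavy atoms (1 carbon, 2 oxygen, 1 sulfur; no ring) in place of a group of 3 heavy atoms (1 carbon, 1 oxygen, 1 sulfur; no ring), on an aromatic carbon. The entering methylsulfonyl sits on an aromatic carbon of a five-membered aromatic ring with 3 nitrogen, between two ring nitrogen atoms.

Among the measured compounds shown here, one measured step bears on this change, as it also alters the group on that carbon: a step that the two limits leave unreadable from compound 2 to compound 3. It offers no size to carry over. The expectation for compound 4 therefore rests on compound 3 at > 200 mg/kg, a limit, and it is for no shift beyond the usual scatter. The expected change is a number no higher from compound 3 to compound 4 (the limit leaves the size open). A reported limit is the likeliest outcome, although a measurable number cannot be ruled out. For compound 4 the estimated value is 200 mg/kg, with an expected range from 80 mg/kg to 400 mg/kg.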

Compound 4, dose for half-maximal effect: > 200 mg/kg
Compound 4: no number, only a limit (the forecaster's own chance of this, stated with the estimate: 75%); the middle value sits exactly at the limit.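

In this assay compound 4 gives > 200 mg/kg, which is a limit. Compound 2 and compound 3 are also reported only as limits, so the steps from either of them to compound 4 cannot be read. The compounds shown leave open whether any group on that aromatic carbon gives a measurable number on the shared core.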